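Adding a methoxy to compound 2: expected effect

The compounds below may be only part of what the source reports. "The series", "measured", "known", "first", "only" and "open" are said of these compounds alone.

In a functional assay on CCRF-CEM cells (Homo sapiens) for inhibition, read by MTT assay, with a stated time of 72 h (a higher number here means a weaker inhibitor, a lower number a stronger inhibitor), compound 1 (`COc1cc(NC(=O)/C=C/c2cccc(OCc3ccccc3)c2)cc(OC)c1OC`) gives 17300 nM and compound 2 (`C=C(Br)C(=O)Nc1cccc(/C=C/C(=O)Nc2cc(OC)cc(OC)c2)c1`) gives 11 nM. Compound 2 holds the lower of the two numbers, with a gap beyond the scatter. Compound 3 (`C=C(Br)C(=O)Nc1cccc(/C=C/C(=O)Nc2cc(OC)c(OC)c(OC)c2)c1`) comes from compound 2 by one change, methoxy in place of hydrogen on an aromatic carbon, ortho to two methoxy groups and para to a large group. No measured pair differs in one place only, so the size of this change is not shown directly. A small step towards a higher number is expected, estimated as a 1.6-fold higher number from compound 2 to compound 3 (0.21 log units; within the scatter). For compound 3 the estimated value is 18 nM, with an expected range of 5 nM to 70 nM.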

Compound 3, half-maximal inhibitory concentration: 59 nM
Beside the measured number, compound 3's estimate is 3.3-fold (0.52 log units) below it, within the range that was stated.
By their numbers in this assay, from the lowest: compound 2; then compound 3; then compound 1.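

In this assay methoxy in place of hydrogen, ortho to two methoxy groups and para to a large group, is not a neutral change: it gives a 5.4-fold higher number from compound 2 to compound 3 (0.73 log units; beyond the scatter) and so a weaker inhibitor. ((1-Bromoethenyl)carbonyl)amino in place of benzyloxy gives a 290-fold lower number from compound 1 to compound 3 (2.47 log units; beyond the scatter) and is the far larger of the two steps. No measurement at hand offers a cause for either step.

Open, from the compounds shown here alone, is whether a hydroxyl or an amine at this position would behave like the methoxy, and whether the methoxy step holds with groups other than ((1-bromoethenyl)carbonyl)amino.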